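Azetidinone series: aryl variation on the saturated ring carbon

The source may report more compounds than this note shows. Statements on the series, on what has been measured and on what is new or still open speak of the compounds shown alone.

Measured so far:
compound 1 `COc1cc(N2C(=O)[C@@H](Oc3ccccc3)[C@H]2c2cccc3ccccc23)cc(OC)c1OC` — 53000 nM
compound 2 `COc1ccc([C@@H]2[C@H](Oc3ccccc3)C(=O)N2c2cc(OC)c(OC)c(OC)c2)cc1[N+](=O)[O-]` — 69000 nM

In a functional assay on MCF7 cells (Homo sapiens) for antiproliferative activity, read by MTT assay, with stated times of 24 h and 72 h (on this read-out lower numbers stand for stronger inhibition and higher numbers for weaker inhibition), compound 1 gives 53000 nM and compound 2 gives 69000 nM. Among the compounds with values here, compound 2 sits within the scatter of compound 1, its only neighbour among the measured numbers. Within the data shown here, the single step at this position, a 1.3-fold higher number from compound 1 to compound 2 (0.11 log units; within the scatter), did not leave the scatter.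

Compound 3 `COc1cc(N2C(=O)[C@@H](Oc3ccccc3)[C@H]2c2cccc(O)c2)cc(OC)c1OC` carries the change (3-hydroxyphenyl in place of 4-methoxy-3-nitrophenyl on a saturated ring carbon). Among the measured compounds shown here, only that one measured step bears on it, and it was flat, so in this assay no step beyond the scatter is expected; the estimated step is a 1.4-fold lower number from compound 2 to compound 3 (0.14 log units; within the scatter). Compound 3 is therefore expected to give 50000 nM, with a range of 15000 nM to 160000 nM.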

Compound 3, half-maximal inhibitory concentration: 54000 nM
Compound 3: the middle estimate sits 1.1-fold (0.03 log units) below what was measured, and the stated range covers the measured number.
By their numbers in this assay, from the lowest: compounds 1, 3 and 2 (each within the scatter of the next).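

In this assay the saturated ring carbon has now carried three different aryl groups with every step inside the scatter, as a 1.3-fold lower number from compound 2 to compound 3 (0.11 log units; within the scatter) and a 1.0-fold higher number from compound 1 to compound 3 (0.01 log units; within the scatter) both show. Even the move to 3-hydroxyphenyl, with 7 heavy atoms and 1 hydrogen-bond donor against 11 heavy atoms and 0 donors in 4-methoxy-3-nitrophenyl, leaves the number within the scatter. No supporting data bear on why this position is so flat.

On these data alone, whether an amine or a carboxylic acid on this ring carbon would produce a step beyond the scatter remains open. So does the effect of replacing the phenoxy group.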